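Aryl Thioether Variation at the Sulfur of a Nucleoside Core

This account rests on a few compounds, and the source may have more. Where it says the series, first, only, none or still open, it means among the compounds named here.

Compound 1, `Nc1nc(SCc2ccc(Br)cc2)c2ncn([C@@H]3O[C@H](CO)[C@@H](O)[C@H]3O)c2n1`: in an assay on isolated protein for binding affinity to Equilibrative nucleoside transporter 1 (Homo sapiens) (a higher number here means a weaker inhibitor, a lower number a stronger inhibitor), compound 1 gives 813 nM.
Compound 2, `Nc1nc(SCCc2ccccc2)c2ncn([C@@H]3O[C@H](CO)[C@@H](O)[C@H]3O)c2n1`: in this assay compound 2 gives 16200 nM.

Within the data shown here, compound 2 stands highest of the two numbers; the single measured step is a 20-fold higher number from compound 1 to compound 2 (1.30 log units; beyond the scatter). Compound 3, `CC(=O)c1ccccc1Sc1nc(N)nc2c1ncn2[C@@H]1O[C@H](CO)[C@@H](O)[C@H]1O`, carries the change (2-acetylphenyl in place of phenethyl on a sulfur). Among the measured compounds shown here, only that one step bears on changes at this sulfur, and it shows the group there can move the number a long way. Because of a 20-fold higher number from compound 1 to compound 2 (1.30 log units; beyond the scatter) a sizable shift is plausible, and compound 3 is expected to give a lower number than compound 2, a 4.1-fold lower number from compound 2 to compound 3 (0.61 log units; beyond the scatter), with wide uncertainty. The estimate for compound 3 is 4000 nM, between 600 nM and 30000 nM.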

Compound 3, half-maximal inhibitory concentration: 447000 nM
The estimate for compound 3 lay 110-fold (2.05 log units) below the measured number; measured number outside the range, above it.
By their numbers in this assay, from the lowest: compound 1; then compound 2; then compound 3.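

In this assay, the change to 2-acetylphenyl on the sulfur gives a 28-fold higher number from compound 2 to compound 3 (1.44 log units; beyond the scatter) and a 550-fold higher number from compound 1 to compound 3 (2.74 log units; beyond the scatter). Compound 3 is thus the weakest of the three, showing that this sulfur tolerates a ring without a saturated chain carbon far less well than either chain-linked group. No measurement shown accounts for this rise. From the compounds shown here alone, the step removes the chain and adds the acetyl together, so their separate shares stay open. Going by these compounds, whether a plain phenyl or a 2-aminophenyl on the sulfur would recover the lost ground also remains unknown.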